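This account rests on a few compounds, and the source may have more. Where it says the series, first, only, none or still open, it means among the compounds named here.

Compound 1, `COc1cc(-c2nn(-c3cccc(NC(=O)Nc4ccc(Cl)c(Cl)c4)c3)cc2-c2ccncc2)ccc1Cl`, gives 1440 nM in a functional assay on HOP-62 cells (Homo sapiens) for inhibition, read by sulforhodamine B assay, with a stated time of 48 h; on this read-out higher numbers stand for weaker inhibition of growth and lower numbers for stronger inhibition of growth.
Compound 2, `O=C(Nc1cccc(-n2cc(-c3ccncc3)c(-c3ccc(Cl)c(O)c3)n2)c1)Nc1ccc(Cl)c(Cl)c1`, gives 2080 nM in this assay.
Compound 3, `O=C(Nc1cccc(-n2cc(-c3ccncc3)c(-c3ccc(Cl)c(O)c3)n2)c1)Nc1cc(C(F)(F)F)cc(C(F)(F)F)c1`, gives 964 nM in this assay.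

All three numbers lie within the usual scatter of one another, so none of these compounds can be called stronger or weaker than another. The nearest to compound 1 is compound 2, reached by the step of a 1.4-fold higher number from compound 1 to compound 2 (0.16 log units; within the scatter); the furthest is compound 3.

Compound 4, `COc1cc(-c2nn(-c3cccc(NC(=O)Nc4ccc(Cl)c(C(F)(F)F)c4)c3)cc2-c2ccncc2)ccc1Cl`, differs from compound 1 by trifluoromethyl in place of chloro on an aromatic carbon. Within the data shown here, the one step measured so far, a 1.4-fold higher number from compound 1 to compound 2 (0.16 log units; within the scatter), concerns an oxygen on the other end of the molecule and says nothing about this change. Compounds 2 and 3 differ on the same ring, where two chloro groups give way to two trifluoromethyl groups; compound 2 gives 2080 nM and compound 3 gives 964 nM, and the two values stay within the scatter. The expectation for compound 4 in this assay is therefore a step from compound 1 of about a 1.2-fold lower number from compound 1 to compound 4 (0.08 log units; within the scatter), that is, no change beyond the scatter. Compound 4 is estimated at 1200 nM, between 500 nM and 2800 nM.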

Compound 4, concentration for 50% growth inhibition: 1310 nM
Compound 4: the middle estimate sits 1.1-fold (0.04 log units) below what was measured, within the range that was stated.
By their numbers in this assay, from the lowest: compounds 3, 4, 1 and 2 (each within the scatter of the next, the first and the last beyond it).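

Among these compounds, replacing one chloro with trifluoromethyl on the 3,4-dichlorophenyl group gives the first reading of a single change on this ring, on an aromatic carbon ortho to a chloro group: in this assay the step is a 1.1-fold lower number from compound 1 to compound 4 (0.04 log units; within the scatter). Compounds 2 and 3 differ at two places on that ring, so they could not show what this one position tolerates on its own. Here, a group of 4 heavy atoms stands where 1 heavy atom stood, and the read-out stays within the scatter, though nothing measured here explains that result.

The compounds shown leave open whether this position would stay as undemanding with an amine or a carboxylic acid in place of the chloro. They also leave open whether the same holds for the remaining chloro on this ring.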